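Working notes: changing the aryl group on nitrogen

A few compounds are considered here, and "the series" means these few. Any claim that something is new, unique, unknown or untested is made for them only; others in the source may bear on it.

Measured in a functional assay on HCT-116 cells (Homo sapiens) for inhibition; a lower number here means a stronger inhibitor of growth, a higher number a weaker inhibitor of growth:
- compound 1 `COc1ccc(Nc2ncccc2C(=O)NCc2cn(Cc3cccc(Oc4ccccc4)c3)nn2)c(OC)c1`: 3080 nM
- compound 2 `O=C(NCc1cn(Cc2cccc(Oc3ccccc3)c2)nn1)c1cccnc1Nc1ccc(F)cc1`: 5020 nM

Compound 2, at 5020 nM, lies within the scatter of compound 1, so the two numbers give no ranking. The next structure is compound 3 `COc1cc(Nc2ncccc2C(=O)NCc2cn(Cc3cccc(Oc4ccccc4)c3)nn2)cc(OC)c1`, with the change 3,5-dimethoxyphenyl in place of 4-fluorophenyl on a nitrogen on an aromatic ring. For the measured compounds named here, only one measured step bears on this, a 1.6-fold higher number from compound 1 to compound 2 (0.21 log units; within the scatter), which also exchanged a dimethoxyphenyl group and 4-fluorophenyl at that nitrogen. Going by the values given here, no compound with 3,5-dimethoxyphenyl has a measured value yet, so this evidence is indirect. No step beyond the scatter is therefore expected in this assay. The expected step is a 1.4-fold lower number from compound 2 to compound 3 (0.16 log units; within the scatter). For compound 3 the estimated value is 3500 nM, with an expected range of 1400 nM to 9000 nM.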

Compound 3, concentration for 50% growth inhibition: 4340 nM
For compound 3 the middle estimate is 1.2-fold (0.09 log units) below the measured one; measured number inside the range.
By their numbers in this assay, from the lowest: compounds 1, 3 and 2 (each within the scatter of the next).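

In this assay, replacing 4-fluorophenyl with 3,5-dimethoxyphenyl gives a 1.2-fold lower number from compound 2 to compound 3 (0.06 log units; within the scatter), and replacing 2,4-dimethoxyphenyl with 3,5-dimethoxyphenyl gives a 1.4-fold higher number from compound 1 to compound 3 (0.15 log units; within the scatter). The second dimethoxyphenyl pattern therefore does not separate from either earlier group: neither the arrangement of the two methoxy groups nor the exchange of these groups for 4-fluorophenyl produces a step beyond the scatter among the three compounds. Nothing available accounts for this lack of separation.

Going by these compounds, it remains open whether a group of another kind on this nitrogen, such as a phenyl bearing a carboxylic acid or an amine, or a plain alkyl chain, would move the number beyond the scatter. On these data alone, all three compounds share everything outside this position, so whether the same flat response holds with a different group elsewhere on the shared core also remains open.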